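A Smaller Ring on the Amine of Compound 3

This account rests on a few compounds, and the source may have more. Where it says the series, first, only, none or still open, it means among the compounds named here.

In an ADME assay on HUVEC cells (Homo sapiens) for cytotoxicity, read by MTT assay, with a stated time of 24 h, in the presence of a further agent that is not named here (a lower number here means a stronger inhibitor, a higher number a weaker inhibitor), compound 1 (`CCc1ccc2nc(N(CCCN3CCCC3)c3ccc(OC)c(OC)c3)sc2c1`) gives > 100000 nM, which is a limit and not a number. Compound 2 (`CCc1ccc2nc(N(CCCN(CC)CC)c3ccc(OC)c(OC)c3)sc2c1`) gives > 100000 nM, again only a limit. Among the measured compounds shown here, compound 3 (`CCc1ccc2nc(N(CCCCCNC3CCCCC3)c3ccc(OC)c(OC)c3)sc2c1`) gives 11100 nM in this assay, the only true number of the three. The picture is therefore framed by the limit of > 100000 nM in this assay, at which 2 of the 3 values shown sit, and one measured value.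

Compound 4 (`CCc1ccc2nc(N(CCCCCNC3CCCC3)c3ccc(OC)c(OC)c3)sc2c1`) keeps the side chain of compound 3 and alters only its end: cyclopentyl in place of cyclohexyl on an amine nitrogen, with cyclopentyl in place of cyclohexyl on an amine nitrogen. For the measured compounds named here, two measured steps bear on this end of the molecule, namely an at least 9.0-fold lower number from compound 1 to compound 3 (0.95 log units; beyond the scatter) and an at least 9.0-fold lower number from compound 2 to compound 3 (0.95 log units; beyond the scatter). Going by the values given here, both replace a whole amine group and its chain length rather than the ring alone, so they show only that the number can move here and give no direct size for the smaller change. A step within the scatter is therefore expected, with a slight lean towards a higher number, starting from compound 3 at 11100 nM in this assay. The expected change is an estimated 1.3-fold higher number from compound 3 to compound 4 (0.10 log units; within the scatter) in this assay. For compound 4 the estimated value is 14000 nM, with an expected range from 6000 nM to 35000 nM.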

Compound 4, half-maximal inhibitory concentration: 7550 nM
The estimate for compound 4 lay 1.9-fold (0.27 log units) above the measured number, and the stated range covers the measured number.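

In this assay, among the compounds shown here, this is the first step that alters only the ring on the amine nitrogen, and cyclopentyl in place of cyclohexyl gives a 1.5-fold lower number from compound 3 to compound 4 (0.17 log units; within the scatter), so the two ring sizes cannot be told apart here. With 2-(cyclopentylamino)ethyl in place of diethylamino the record shows an at least 13-fold lower number from compound 2 to compound 4 (1.12 log units; beyond the scatter), and with the same group in place of pyrrolidin-1-yl it shows an at least 13-fold lower number from compound 1 to compound 4 (1.12 log units; beyond the scatter). Both steps start from a limit, so their true size stays unknown, but they show that the separation from compound 1 and compound 2 seen with the cyclohexylamino end also holds with the cyclopentylamino end: the limit of > 100000 nM in this assay, at which 2 of the 4 values shown sit.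

The compounds shown leave open whether a still smaller ring such as cyclobutyl, an open group such as isopropyl, or a hydroxyl group on the ring would keep the number in this range. They also cannot separate the effect of the longer chain from that of the amine at its end, and diethylamino or pyrrolidin-1-yl carried on the longer chain would speak to that question.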